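The source may hold more compounds than are shown below. What is called first, only, known or untested is meant among the compounds shown, and "the series" means these compounds.

Working notes on the series. Compound 1 `N/C(=N\NC(=S)N1CCCCCC1)c1ccccn1`, compound 2 `N/C(=N\NC(=S)N1CCOCC1)c1ccccn1` and compound 3 `N/C(=N\NC(=S)N1CCOCC1)c1ccc(F)cn1` have been run in a functional assay on A-431 cells (Homo sapiens) for cytotoxicity, read by MTT assay, with a stated time of 72 h, tested at 100 uM; on this read-out higher numbers stand for more inhibition of growth at the one concentration tested and lower numbers for less inhibition of growth. In this assay compound 1 gives 77.5%. In this assay compound 2 gives 84.6%, and compound 3 gives 85.6%. All three numbers sit within the scatter of one another, so no order among them is claimed. The difference between the core of compound 1 and the core of compound 2 is not broken down here.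

Compound 2 and compound 3 differ in one place: fluoro in place of hydrogen on an aromatic carbon. This change made a number 1 percentage points higher from compound 2 to compound 3 (within the scatter), a step within the scatter.

Compound 4 `N/C(=N\NC(=S)N1CCCCCC1)c1ccc(F)cn1` is not yet measured in this assay. Relative to compound 1 it carries the same change, at a place described in identical words: fluoro in place of hydrogen on an aromatic carbon. Among the measured compounds shown here, the only measured instance of this change gave a number 1 percentage points higher from compound 2 to compound 3 (within the scatter), so a step of about the same size is expected here, namely a number 1.5 percentage points higher from compound 1 to compound 4 (within the scatter). This rests on a single prior instance and on the scatter of such single-concentration growth inhibition readings. For compound 4 the expected value in this assay is estimated at 79%, likely between 69% and 89%.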

Compound 4, percent growth inhibition at one concentration: 83.5%
Estimate against measurement, compound 4: 4.5 percentage points below; measured number inside the range.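

On the core of compound 1, fluoro in place of hydrogen on an aromatic carbon gave a number 6 percentage points higher from compound 1 to compound 4 (within the scatter) in this assay. The two instances of this change do not differ from each other beyond what repeated measurements would give: the same change on two cores in this assay, a number 1 percentage points higher (within the scatter) from compound 2 to compound 3 and a number 6 percentage points higher (within the scatter) from compound 1 to compound 4, 5 percentage points apart, within the scatter of two such steps

Since each step lies within the scatter, the pair fits a change that carries from one core to the other without a visible difference, but it does not establish a real gain in growth inhibition on either core, and two cores read at one concentration say nothing about any further core.

The compounds shown carry only hydrogen or fluoro at this aromatic carbon, so the outcome with a chloro, a methoxy or a nitrile there stays open. Also open, from the compounds shown here alone, is how an open-chain dimethylamine would read in this assay in place of the ring that separates compound 1 from compound 2.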